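The source may hold more compounds than are shown below. What is called first, only, known or untested is meant among the compounds shown, and "the series" means these compounds.

Three acids of one series have been run in an in vitro functional assay on HEK285-7 cells for antagonist activity at prostaglandin D2 receptor 2 (Homo sapiens), read by BRET and beta-arrestin recruitment; on this read-out lower numbers stand for smaller maximal responses and higher numbers for larger maximal responses. Compound 1 `O=C(O)Cc1sc(C(c2ccccc2)c2ccccc2)nc1-c1ccc(C(F)(F)F)cc1` gives 80%. Compound 2 `NS(=O)(=O)c1ccc(-c2nc(C(c3ccc(F)cc3)c3ccc(F)cc3)sc2CC(=O)O)cc1` gives 80% in this assay. Compound 3 `O=C(O)Cc1sc(C(c2ccccc2)c2ccc(Cl)cc2)nc1-c1ccc(Cl)cc1` gives 80% in this assay. Compound 2 thus stands level with compound 1 and compound 3 at the digits shown; its nearest neighbour is compound 1 and its furthest is compound 3, and both gaps lie within the scatter. Compound 4 `CS(=O)(=O)Nc1cccc(-c2nc(C(c3ccc(F)cc3)c3ccc(F)cc3)sc2CC(=O)O)c1` is not yet measured. It differs from compound 2 in one place: 3-(methanesulfonamido)phenyl in place of 4-sulfamoylphenyl on an aromatic carbon. Going by the values given here, no step between measured compounds covers this change, so no move beyond the scatter in this assay is expected in either direction. Compound 4 is expected to give 80% in this assay, with a range from 66% to 92%. The expected step is no change at the digits printed from compound 2 to compound 4 (within the scatter), within the scatter.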

Compound 4, largest response reached (reported as efficacy), in percent of the reference or control that the assay uses: 80%
Estimate against measurement, compound 4: no gap at the digits printed, within the range that was stated.
By their numbers in this assay, from the lowest: compounds 1, 2, 3 and 4 (each within the scatter of the next).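

In this assay, moving from 4-sulfamoylphenyl to 3-(methanesulfonamido)phenyl on the aromatic carbon next to the ring nitrogen gives no change at the digits printed from compound 2 to compound 4 (within the scatter), the first step read at this position. The maximal response therefore holds across this one change, with the two diaryl-substituted acids sharing everything else. The two groups have matching hydrogen-bond donor and acceptor counts, so this pair does not test a change in those counts.

From the compounds shown here alone, whether an amine or a morpholine in place of the sulfonamide group would leave the response level remains open. No measurement shown bears on the reason for this result.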